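The compounds below may be only part of what the source reports. "The series", "measured", "known", "first", "only" and "open" are said of these compounds alone.

Measured in a functional assay on MGC-803 cells (Homo sapiens) for antiproliferative activity, read by MTT assay, with a stated time of 48 h; on this read-out lower numbers stand for stronger inhibition and higher numbers for weaker inhibition:
- compound 1 `COc1ccc(CN(C(=O)CSc2nc3ccccc3s2)c2cc(OC)c(OC)c(OC)c2)cc1O`: 35 nM
- compound 2 `COc1cc(N(Cc2ccccc2)C(=O)CSc2nc3ccccc3s2)cc(OC)c1OC`: 44300 nM

Of these two, compound 1 has the lower number and is therefore the stronger inhibitor in this assay, and the gap between them lies beyond the usual scatter. Compound 3 `COc1ccc(CN(C(=O)CSc2nc3ccccc3s2)c2cc(OC)c(OC)c(OC)c2)cc1F` has not yet been measured. It differs from compound 1 in a single group, with fluoro in place of hydroxy on an aromatic carbon, so that 3-hydroxy-4-methoxybenzyl becomes 3-fluoro-4-methoxybenzyl.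

Among the compounds with values here, only one measured step bears on this change: a 1300-fold higher number from compound 1 to compound 2 (3.10 log units; beyond the scatter), which is large. That step removes the hydroxy and the methoxy together, so the data do not show how much of it belongs to the hydroxy alone. Compound 3 keeps the methoxy and loses only the hydroxy. A rise beyond the scatter is therefore expected, but a smaller one than the large step seen for compound 2 in a 1300-fold higher number from compound 1 to compound 2 (3.10 log units; beyond the scatter). The expected change is a 14-fold higher number from compound 1 to compound 3 (1.15 log units; beyond the scatter). Compound 3 is expected at 500 nM, with an estimated range of 60 nM to 5000 nM.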

Compound 3, half-maximal inhibitory concentration: 416 nM
Estimate against measurement, compound 3: 1.2-fold (0.08 log units) above, and the stated range covers the measured number.
By their numbers in this assay, from the lowest: compound 1; then compound 3; then compound 2.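

In this assay, within the data shown here, exchanging the hydroxy for fluoro while the methoxy stays gives a 12-fold higher number from compound 1 to compound 3 (1.08 log units; beyond the scatter), so this single carbon of the benzyl ring matters by itself, even though only one heavy atom changes and the one hydrogen-bond donor of this group is lost. The change in the other direction is just as informative: a 110-fold lower number from compound 2 to compound 3 (2.03 log units; beyond the scatter) shows that a ring with no hydroxy at all, carrying 3-fluoro-4-methoxy, still stands far ahead of the plain phenyl. The hydroxy therefore does not account for the whole of the large gap seen earlier, and the ring substituents other than the hydroxy also carry much of the activity.

The compounds shown leave open whether an amine or a chloro on this same carbon would stay close to compound 1 or fall nearer compound 3, and how much the methoxy contributes with hydrogen in the place of the hydroxy. Nothing available here explains why the exchange of hydroxy for fluoro raises the number.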